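Cytotoxicity of an ester-bearing thioether amide series

This account rests on a few compounds, and the source may have more. Where it says the series, first, only, none or still open, it means among the compounds named here.

Three related compounds have been tested in an ADME assay on CEM-SS cells (Homo sapiens) for cytotoxicity, read by XTT assay, with a stated time of 6 days (on this read-out higher numbers stand for lower toxicity in this test and lower numbers for higher toxicity in this test), and a fourth awaits testing. Compound 1 has the structure `CCCC(=O)OCSc1ccccc1C(=O)NCCC(N)=O`. In this assay compound 1 gives only a limit, > 100 uM, and no number. Compound 2, `NC(=O)CCNC(=O)c1cccc(S)c1`, also reaches only a limit in this assay, at > 100 uM. Compound 3, `CCCC(=O)OCSc1ccccc1C(=O)Nc1ccccc1C(N)=O`, gives a measured value in this assay of 50.1 uM. So compound 1 sits at the limit of > 100 uM in this assay, at which 2 of the 3 values shown sit, the point where most of the shown values rest, and no numerical reading for it exists.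

Compound 4, `CCCC(=O)OCSc1ccccc1C(=O)NCC(=O)NCCN(C)C`, shares the core of compound 1 and differs from it in one place: (2-(dimethylamino)ethyl)carbamoyl in place of carbamoylmethyl on a saturated chain carbon bound to an amide-type nitrogen. Among the compounds with values here, no pair of measured compounds carries this change, so its effect on this assay is unknown. On the evidence of compound 1 at > 100 uM, little movement beyond the usual scatter is expected, and the step from compound 1 to compound 4 is estimated as a number no higher from compound 1 to compound 4 (the limit leaves the size open). For compound 4 the expected value in this assay is 100 uM, within a range of 40 uM to 300 uM, most likely again reported as a limit.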

Compound 4, half-maximal toxic concentration: 76.9 uM
Compound 4: middle estimate off by 1.3-fold (0.11 log units), on the high side, within the range that was stated.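

Replacing carbamoylmethyl with (2-(dimethylamino)ethyl)carbamoyl, on a saturated chain carbon bound to an amide-type nitrogen, gives a measured number at this position in this assay, with an at least 1.3-fold lower number from compound 1 to compound 4 (0.11 log units; that floor lies within the scatter). Compound 1 gives only a limit, > 100 uM, so that step is the smallest the two readings allow, and the real gap could be larger. The larger group therefore moves compound 4 off the limit, but whether its number truly differs from that of compound 1 beyond the usual scatter cannot be told, because compound 1 rests on a limit: the limit of > 100 uM in this assay, at which 2 of the 4 values shown sit.

The compounds shown leave open whether a carboxylic acid or a simple primary amine at the end of this chain would give a different number in this assay. They also leave open how a longer chain carrying the same dimethylamino end would read.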